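A few compounds are considered here, and "the series" means these few. Any claim that something is new, unique, unknown or untested is made for them only; others in the source may bear on it.

Measured in an ADME assay on L6 cells (Rattus norvegicus) for cytotoxicity; on this read-out higher numbers stand for weaker inhibition and lower numbers for stronger inhibition:
compound 1 `CC1CCc2ccccc2N1S(=O)(=O)c1ccccc1` gives 70000 nM;
compound 2 `Cc1ccc(S(=O)(=O)N2c3ccccc3CCC2C)cc1` gives 4900 nM;
compound 3 `CC1CCc2ccccc2N1S(=O)(=O)c1ccc(N)cc1` gives 35300 nM.

Compound 3 stands second highest of the three numbers, with compound 1 within the scatter of it and compound 2 clearly apart (a 7.2-fold higher number from compound 2 to compound 3 (0.86 log units; beyond the scatter)). Compound 4 `CC1CCc2ccccc2N1S(=O)(=O)c1ccc(Cl)cc1` differs from compound 3 by chloro in place of amino on an aromatic carbon. For the measured compounds named here, two measured steps bear on this: a 2.0-fold lower number from compound 1 to compound 3 (0.30 log units; within the scatter), within the scatter, and a 7.2-fold higher number from compound 2 to compound 3 (0.86 log units; beyond the scatter), beyond it; the latter shows that swapping the amino for a group with no donor or acceptor went with a clearly lower number. Going by the values given here, a lower number in this assay is therefore expected for compound 4, of roughly the size seen with methyl, though no chloro analogue is on hand to confirm it. Compound 4 is estimated at 8000 nM (range 3000 nM to 25000 nM), which means an expected step of a 4.4-fold lower number from compound 3 to compound 4 (0.64 log units; beyond the scatter).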

Compound 4, half-maximal inhibitory concentration: 20500 nM
For compound 4 the middle estimate is 2.6-fold (0.41 log units) below the measured one; the range from low to high includes it.
By their numbers in this assay, from the lowest: compound 2; then compounds 4, 3 and 1 (each within the scatter of the next, the first and the last beyond it).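

In this assay, chloro para to a large group cannot be told apart from amino (a 1.7-fold lower number from compound 3 to compound 4 (0.24 log units; within the scatter)). Removing the hydrogen-bond donor and acceptor of the amino therefore does not by itself give the methyl result: chloro also has neither, yet stays clearly apart from methyl (a 4.2-fold higher number from compound 2 to compound 4 (0.62 log units; beyond the scatter)), while also parting from hydrogen (a 3.4-fold lower number from compound 1 to compound 4 (0.53 log units; beyond the scatter)). Nothing available accounts for the gap between chloro and methyl.

On these data alone, whether ethyl or a longer chain at this position would follow methyl remains open. So does the place of methoxy or a carboxylic acid there.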